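Predicting a Side-Chain Swap on a Second Core

This account rests on a few compounds, and the source may have more. Where it says the series, first, only, none or still open, it means among the compounds named here.

Measured compounds:
- compound 1, `NC(=O)CC[C@H](NC(=O)CN(c1ncnc2c1ncn2C1CCCCO1)C1CC1)C(=O)OCc1ccccc1`: 39.4%
- compound 2, `CC(C)C[C@H](NC(=O)CN(c1ncnc2c1ncn2C1CCCCO1)C1CC1)C(=O)OCc1ccccc1`: 34.2%
- compound 3, `CC(C)C[C@H](NC(=O)CN(c1nc(Cl)nc2[nH]cnc12)C1CC1)C(=O)O`: 36.4%

Of the compounds shown here, three have been tested in a functional assay on the whole organism (Tail, strain ICR) with Mus musculus as the target, in the tail flick test, with a stated time of 60 min, at a dose of 25 umol/kg by the oral route; on this read-out lower numbers stand for a weaker effect and higher numbers for a stronger effect at the one dose given. In this assay compound 1 gives 39.4%, compound 2 gives 34.2%, and compound 3 gives 36.4%. All three numbers lie within the scatter of one another, so none can be called more or less active than the others.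

Compound 1 and compound 2 share one core and differ in a single place: carbamoylmethyl in place of isopropyl on a saturated chain carbon, two bonds along the chain from an amide-type nitrogen and a carbonyl carbon. The step that this change made is a number 5.2 percentage points higher from compound 2 to compound 1 (within the scatter).

Compound 3 carries a different core from compound 2; the difference between the two cores is not broken down here. Compound 4, `NC(=O)CC[C@H](NC(=O)CN(c1nc(Cl)nc2[nH]cnc12)C1CC1)C(=O)O`, has not yet been measured. It stands to compound 3 exactly as compound 1 stands to compound 2: carbamoylmethyl in place of isopropyl on a saturated chain carbon, two bonds along the chain from an amide-type nitrogen and a carbonyl carbon. Since the change is the same, on a core of the same family, the expected step from compound 3 to compound 4 is a number 3.6 percentage points higher from compound 3 to compound 4 (within the scatter), resting on the step of a number 5.2 percentage points higher from compound 2 to compound 1 (within the scatter) and on the measured value of compound 3, 36.4%. The estimate for compound 4 in this assay is therefore 40%, with an expected range from 28% to 52%.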

Compound 4, a percentage reported as activity, at one dose (the size of the read-out at that dose, not a potency): 38.4%
Compound 4: middle estimate off by 1.6 percentage points, on the high side; low and high end bracket the measured number.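

In this assay, carbamoylmethyl in place of isopropyl on the saturated chain carbon gives a number 2 percentage points higher from compound 3 to compound 4 (within the scatter). Set beside the same change on the core of compound 1 and compound 2, this step shows no sign that the core alters what the change does: the same change on two cores in this assay, a number 5.2 percentage points higher (within the scatter) from compound 2 to compound 1 and a number 2 percentage points higher (within the scatter) from compound 3 to compound 4, 3.2 percentage points apart, within the scatter of two such steps. Among the compounds shown here, this agreement is limited, however, since both steps are small enough to lie within the scatter, so the two pairs show only that the change gave no clear rise or fall on either core, not that it has a real effect that carries from one core to the other.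

The compounds shown leave open whether a side chain with a stronger effect on this read-out exists at this place, for example one ending in a carboxylic acid or an amine in place of the carbamoylmethyl, or a chain longer than 2-carbamoylethyl. From the compounds shown here alone, a group that moved the number beyond the scatter on one core would give a far sharper test of transfer, and whether the two cores would still agree at other doses or times also remains open.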